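Second Chlorine on the Pendant Phenyl of Compound 1

The source may report more compounds than this note shows. Statements on the series, on what has been measured and on what is new or still open speak of the compounds shown alone.

Compound 1 `Cc1nc(N[C@@H]2C[C@H]3CC[C@@H]2C3)c2cc(-c3ccc(Cl)cc3)ccc2n1` gives 47% in an ADME assay (Homo sapiens) for metabolic stability; on this read-out lower numbers stand for a less stable compound and higher numbers for a more stable compound. Going by the values given here, its only measured neighbour, compound 2 `Cc1nc(N[C@@H]2C[C@H]3CC[C@@H]2C3)c2cc(-c3cccc(Cl)c3)ccc2n1`, gives 50% in this assay; the two numbers lie within the usual scatter of each other, and the step of a number 3 percentage points higher from compound 1 to compound 2 (within the scatter) is the only measured step in this set, so compound 1 has no measured partner that differs from it beyond the scatter. Compound 3 `Cc1nc(N[C@@H]2C[C@H]3CC[C@@H]2C3)c2cc(-c3cc(Cl)cc(Cl)c3)ccc2n1` has not yet been measured in this assay. It differs from compound 1 by 3,5-dichlorophenyl in place of 4-chlorophenyl on an aromatic carbon. The step from compound 1 to compound 2 bears on this change only in part, since it exchanged one chlorophenyl for another rather than adding a chlorine, and it was within the scatter. Among the compounds with values here, a second chlorine has no measured counterpart here. The step expected is therefore a number 1 percentage points lower from compound 1 to compound 3 (within the scatter), nothing beyond the scatter. Compound 3 is expected to give 46% in this assay, with a range from 28% to 64%.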

Compound 3, percent of the compound remaining: 62%
Estimate against measurement, compound 3: 16 percentage points below; the range from low to high includes it.
By their numbers in this assay, from the lowest: compounds 1 and 2 (each within the scatter of the next); then compound 3.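

In this assay, going by these compounds alone, the change from a single chlorine to two gives the first steps in this set that lie beyond the scatter. Exchanging 4-chlorophenyl for 3,5-dichlorophenyl is a number 15 percentage points higher from compound 1 to compound 3 (beyond the scatter), and chloro in place of hydrogen on the 3-chlorophenyl ring is a number 12 percentage points higher from compound 2 to compound 3 (beyond the scatter), so compound 3 stands above both single-chlorine compounds, whereas moving the one chlorine, in a number 3 percentage points higher from compound 1 to compound 2 (within the scatter), gave no separation. No measurement here explains this rise.

From the compounds shown here alone, whether the rise requires a second chlorine, or would also follow from a fluoro, methyl or methoxy group on the same ring, remains open. Going by these compounds, it is also open whether the gain from 3,5-dichlorophenyl would hold if another amine replaced the bridged amine on the shared core.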